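Adding a second chloro to a core already at the limit

A few compounds are considered here, and "the series" means these few. Any claim that something is new, unique, unknown or untested is made for them only; others in the source may bear on it.

Compound 1 `ClCc1ccc(Cn2cnc3c(Cl)ncnc32)cc1`: in a functional assay on K562 cells (Homo sapiens) for cytotoxicity, read by sulforhodamine B assay, with a stated time of 48 h (on this read-out lower numbers stand for stronger inhibition of growth and higher numbers for weaker inhibition of growth), compound 1 gives > 100000 nM, a limit of the assay.
Compound 2 `ClCc1ccc(Cn2cnc3nc(Cl)nc(Cl)c32)cc1`: in this assay compound 2 gives > 100000 nM, likewise a limit of the assay.

Compound 1 thus cannot be placed more closely than at the limit of > 100000 nM in this assay, at which 2 of the 2 values shown sit. Compound 3 `ClCc1ccc(Cn2cnc3c(Cl)nc(Cl)nc32)cc1` differs from compound 1 by chloro in place of hydrogen on an aromatic carbon. No measured step connects two of these compounds, and with compound 1 and compound 2 both sitting at the limit, nothing beyond the usual scatter is expected from this change. The step is expected to be a step that the limit leaves unreadable from compound 1 to compound 3. Compound 3 is estimated at 150000 nM, with a range from 60000 nM to 400000 nM, most likely reported again only as a limit.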

Compound 3, concentration for total growth inhibition: 66100 nM
For compound 3 the middle estimate is 2.3-fold (0.36 log units) above the measured one; low and high end bracket the measured number.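

In this assay, chloro in place of hydrogen on an aromatic carbon between two ring nitrogen atoms gives the first read-out that is a number, not a limit, with an at least 1.5-fold lower number from compound 1 to compound 3 (0.17 log units; that floor lies within the scatter). The other two compounds stay where they were: the limit of > 100000 nM in this assay, at which 2 of the 3 values shown sit. Thus this position can move the read-out off the limit, though the step's floor alone does not establish a change beyond the scatter.

As far as these compounds go, the true size of the step remains open, since compound 1 has only a limit. Also open, from the compounds shown here alone, is whether an amine or a methoxy group at this position would do the same.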